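Hydrogen in place of iodo on compound 3

The source may hold more compounds than are shown below. What is called first, only, known or untested is meant among the compounds shown, and "the series" means these compounds.

In a functional assay on HCT-116 cells (Homo sapiens) for cytotoxicity, with a stated time of 3 days (on this read-out lower numbers stand for stronger inhibition and higher numbers for weaker inhibition), compound 3 (`Ic1nc2ccccc2[se]1`) reads > 40000 nM, which is a limit of the assay and not a number. Compound 2 (`Brc1nc2ccccc2[se]1`) reads > 40000 nM, which is also a limit. Compound 3 therefore stands at the limit of > 40000 nM in this assay, at which 2 of the 3 values shown sit. Among the compounds with values here, compound 1 (`C#Cc1nc2ccccc2[se]1`) is the only one with a number, at 25000 nM.

Compound 4 (`c1ccc2[se]cnc2c1`) carries hydrogen in place of iodo on an aromatic carbon, next to the ring nitrogen and next to the ring selenium: hydrogen in place of iodo on an aromatic carbon.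

Within the data shown here, no measured step has hydrogen as a partner, so the closest evidence is the three steps that exchange the group on this carbon. Bromo in place of ethynyl gives an at least 1.6-fold higher number from compound 1 to compound 2 (0.20 log units; that floor lies within the scatter). Iodo in place of ethynyl gives an at least 1.6-fold higher number from compound 1 to compound 3 (0.20 log units; that floor lies within the scatter). Iodo in place of bromo gives a step that the two limits leave unreadable from compound 2 to compound 3. With only compound 1 at 25000 nM read as a number and no measured step shown beyond the scatter, no step beyond the scatter is expected in this assay.

The estimated step is a number no higher from compound 3 to compound 4 (the limit leaves the size open). The estimate for compound 4 is 40000 nM, with an expected range from 18000 nM to 80000 nM.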

Compound 4, half-maximal inhibitory concentration: > 40000 nM
Compound 4: only a limit was reported; the forecaster's own chance of this, stated with the estimate: 60%; the middle value sits exactly at the limit.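

Working notes on the series: in this assay, replacing the group on this aromatic carbon with hydrogen does not lift compound 4 off the limit, so a compound with no substituent here reads like the bromo and iodo compounds, and its value is a limit, not a number: the limit of > 40000 nM in this assay, at which 3 of the 4 values shown sit.

Hydrogen in place of ethynyl gives an at least 1.6-fold higher number from compound 1 to compound 4 (0.20 log units; that floor lies within the scatter), so compound 4 is not separated from compound 1 beyond the scatter. Within the data shown here, compound 1 at 25000 nM remains the only number. The steps from compound 2 and from compound 3 to compound 4 cannot be read, as both ends of each are limits.

On these data alone, it remains open whether ethynyl on this carbon truly differs from hydrogen, bromo or iodo in this read-out, since the available floors do not exceed the scatter. Also open, as far as these compounds go, is how an amine, a carboxylic acid or a longer alkyne chain on this carbon would read, and whether any such group would give a number clearly below that of compound 1.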